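Propyl to Allyl on the Amine Nitrogen

The source may report more compounds than this note shows. Statements on the series, on what has been measured and on what is new or still open speak of the compounds shown alone.

Of the compounds shown here, two have been measured so far in a functional assay on Caco-2 cells (Homo sapiens), read by fluorescence, tested at 10 uM; on this read-out lower numbers stand for a stronger effect and higher numbers for a weaker effect at the one concentration tested. Compound 1 `CCCNC(=C\C(=O)/C=C/c1ccc(O)c(OC)c1)/C=C/c1ccc(O)c(OC)c1` gives 88% in this assay. Compound 2 `CCC(C)NC(=C\C(=O)/C=C/c1ccc(OC(C)=O)c(OC)c1)/C=C/c1ccc(OC(C)=O)c(OC)c1` gives 86% in this assay. These two numbers lie within the usual scatter of each other, so compound 1 stands with the higher of the two numbers on paper, yet it cannot be told apart from compound 2 on that basis. Both numbers are high, which on this read-out means a weak effect at the one concentration tested.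

Compound 3 `C=CCNC(=C\C(=O)/C=C/c1ccc(O)c(OC)c1)/C=C/c1ccc(O)c(OC)c1` has not been measured. It differs from compound 1 in one place: vinyl in place of ethyl on a saturated chain carbon bound to an amine nitrogen. Going by the values given here, no measured pair shows how this kind of change acts here, so there is no direct guide from the data.

Because compound 1 gives 88% and compound 2 gives a number within the scatter of it, little movement is expected from a small change of this kind. The step of a number 1 percentage points lower from compound 1 to compound 3 (within the scatter) is expected to stay within the scatter, in no set direction. Compound 3 is therefore estimated at 87%, with a range from 72% to 98%.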

Compound 3, a percentage reported as activity, at one concentration (the size of the read-out at that concentration, not a potency): 76%
Compound 3: the middle estimate sits 11 percentage points above what was measured; the measured number falls inside the stated range.
By their numbers in this assay, from the lowest: compounds 3, 2 and 1 (each within the scatter of the next, the first and the last beyond it).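

In this assay, going by these compounds alone, the change from propyl to allyl on the amine nitrogen gives a number 12 percentage points lower from compound 1 to compound 3 (beyond the scatter), the first step in this set that can be read from a single change, and on this read-out a lower number stands for a stronger effect at the one concentration tested. This shows that the group on the amine nitrogen is not a silent position: ethyl and vinyl have the same count of heavy atoms, and the double bond outside aromatic rings is what separates them, so a small edit here can move the number beyond the usual scatter. Nothing available explains why this step occurs.

From the compounds shown here alone, it remains open whether the step belongs to the double bond specifically, or whether a propargyl group, a cyclopropylmethyl group or a longer chain such as butyl on the same nitrogen would move the number as well, or further. Also open, going by these compounds, is whether the same change would act alike on the acetylated core of compound 2, which carries acetate esters in place of the free hydroxyl groups.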